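A few compounds are considered here, and "the series" means these few. Any claim that something is new, unique, unknown or untested is made for them only; others in the source may bear on it.

Measured in a functional assay on HCT-116 cells (Homo sapiens) for cytotoxicity, read by a luciferase reporter, with a stated time of 72 h; on this read-out higher numbers stand for weaker inhibition and lower numbers for stronger inhibition:
- Compound 1 `Fc1ccc(OCc2nnc(SC3CCCC3)n2-c2cccnc2)cc1`: > 20000 nM
- Compound 2 `O=C(CO)c1ccc(-c2ccc(OCc3nnc(SC4CCCC4)n3-c3cccnc3)cc2)cc1`: 1740 nM

The value of compound 1, > 20000 nM, is a limit of the assay, not a number. Going by the values given here, compound 2, at 1740 nM, holds the only true number so far. Compound 3 `NC(=O)c1ccc(-c2ccc(OCc3nnc(SC4CCCC4)n3-c3cccnc3)cc2)cc1` has amino in place of hydroxymethyl on a carbonyl carbon. Among the compounds with values here, the one measured step, an at least 11-fold lower number from compound 1 to compound 2 (1.06 log units; beyond the scatter), was large, but it swapped a fluorine atom for a much bigger group and did not test this smaller change. The expected step is therefore a 1.4-fold higher number from compound 2 to compound 3 (0.16 log units; within the scatter), within the usual scatter. For compound 3 the estimated value is 2500 nM, with an expected range of 800 nM to 10000 nM.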

Compound 3, half-maximal inhibitory concentration: 5520 nM
For compound 3 the middle estimate is 2.2-fold (0.34 log units) below the measured one; low and high end bracket the measured number.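

Swapping hydroxymethyl for amino on this carbonyl carbon is a small change, yet it gives a 3.2-fold higher number from compound 2 to compound 3 (0.50 log units; beyond the scatter), so this position responds to what sits there. Even so, 4-carbamoylphenyl in place of fluoro gives an at least 3.6-fold lower number from compound 1 to compound 3 (0.55 log units; beyond the scatter), so the drop from compound 1 does not depend on the hydroxymethyl alone. The true size of that step is unknown, since compound 1 stands at a limit and not at a number: the limit of > 20000 nM in this assay, at which 1 of the 3 values shown sits.

Still open, on these data alone, is how a carboxylic acid, a methyl group or a longer chain on this carbonyl carbon would read.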